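Furan-2-yl replacing methoxyphenyl on the shared five-membered core

The source may report more compounds than this note shows. Statements on the series, on what has been measured and on what is new or still open speak of the compounds shown alone.

Two measured members of this series are in hand. Compound 1 `O=C(O)CCc1ccc(OCc2coc(-c3cccc(Cl)c3)n2)cc1` gives 160 nM in a functional assay on CHO cells for agonist activity at Free fatty acid receptor 1 (Homo sapiens), read by FLIPR and calcium flux, in the presence of a further agent that is not named here; a lower number here means that less compound is needed, a higher number that more compound is needed for the effect. Compound 2 `COc1cccc(-c2noc(COc3ccc(CCC(=O)O)cc3)n2)c1` gives 2670 nM in this assay, the higher of the two numbers, and its gap to compound 1 lies beyond the usual scatter. Within the data shown here, no step between measured compounds that differ in one place is available, so the effect of any single change on the core of compound 2 is not yet known. Compound 3 `O=C(O)CCc1ccc(OCc2nc(-c3ccco3)no2)cc1` is the next member, differing from compound 2 in one place: furan-2-yl in place of 3-methoxyphenyl on an aromatic carbon. With nothing measured on this exact change, the expected step of a 1.3-fold higher number from compound 2 to compound 3 (0.12 log units; within the scatter) in this assay is judged small, not clearly beyond the scatter, with the direction left open. Compound 3 is therefore estimated at 3500 nM in this assay, within a range of 1000 nM to 12000 nM.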

Compound 3, half-maximal effective concentration: > 100000 nM
Compound 3 ended at the assay's limit; the forecaster's own chance of this, stated with the estimate: 15%; middle value at least 28-fold (1.45 log units) from the limit.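

Among these compounds, on the aromatic carbon between two ring nitrogen atoms, furan-2-yl in place of 3-methoxyphenyl gives an at least 37-fold higher number from compound 2 to compound 3 (1.57 log units; beyond the scatter) in this assay, the first single-place step. The group at this position therefore has a large bearing on the read-out, and 3-methoxyphenyl cannot be exchanged here for furan-2-yl without a loss beyond the scatter. Compound 3 stands at a limit of the assay, so the step marks only a minimum size: the limit of > 100000 nM in this assay, at which 1 of the 3 values shown sits.

The compounds shown leave open whether the step belongs to furan-2-yl itself or to the departure of the six-membered aromatic ring of carbon. Thiophen-2-yl and unsubstituted phenyl at this position would separate these two readings, and the role of the methoxy group also remains unresolved.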